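The compounds below may be only part of what the source reports. "The series", "measured", "known", "first", "only" and "open" are said of these compounds alone.

Three compounds built on the shared core are known. Compound 1 `Cc1nc(C#Cc2ccc(F)cc2)cs1` gives 2970 nM in a functional assay on CHO cells for agonist activity at metabotropic glutamate receptor 5 (Homo sapiens), read by inositol phosphate accumulation; a higher number here means a weaker inhibitor, a lower number a stronger inhibitor; compound 2 `COc1ccccc1C#Cc1csc(C)n1` gives 36.3 nM in this assay; compound 3 `Cc1nc(C#Cc2cccc(Cl)c2)cs1` gives 129 nM in this assay. Compound 3 thus stands second highest of the three numbers: compound 2 sits at a lower value, beyond the scatter, while compound 1 sits at a much higher value, far beyond the scatter. Compound 4 `Cc1nc(C#Cc2cccc(C#N)c2)cs1` carries cyano in place of chloro on an aromatic carbon. For the measured compounds named here, no measured pair follows this particular change, so its size is uncertain. The step of a 1.6-fold lower number from compound 3 to compound 4 (0.21 log units; within the scatter) is expected to be small, toward a somewhat lower number. Compound 4 is therefore estimated at 80 nM, with a range from 25 nM to 300 nM.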

Compound 4, half-maximal inhibitory concentration: 0.94 nM
Compound 4: the middle estimate sits 85-fold (1.93 log units) above what was measured; the whole stated range lies above it.
By their numbers in this assay, from the lowest: compound 4; then compound 2; then compound 3; then compound 1.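

In this assay, cyano in place of chloro on an aromatic carbon gives a 140-fold lower number from compound 3 to compound 4 (2.14 log units; beyond the scatter). This is the first change in one place alone among these compounds, and it shows that the number at this position, meta to a group of 8 heavy atoms, can move far with a single swap of group. Nothing available accounts for the size of this step. Going by these compounds, it remains open how an amine or a carboxylic acid would fare at this position. On these data alone, it also remains open whether cyano would give a similar step on another carbon of the same ring.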